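This account rests on a few compounds, and the source may have more. Where it says the series, first, only, none or still open, it means among the compounds named here.

Working notes on the series. Within the data shown here, compound 1 `Cc1ccc(S/C(=C/c2ccc(Br)cc2)C(=O)c2ccc(Cl)cc2)cc1` is the only member with a number in a functional assay on DU-145 cells (Homo sapiens) for inhibition, read by trypan blue exclusion, with a stated time of 96 h (a lower number here means a stronger inhibitor of growth, a higher number a weaker inhibitor of growth), where compound 1 gives 25000 nM. Compound 2 `Cc1ccc(S/C(=C/c2ccc(N(C)C)cc2)C(=O)c2ccc(Cl)cc2)cc1` differs from compound 1 by bromo in place of dimethylamino on an aromatic carbon. In this assay compound 2 returns only a limit, > 100000 nM. Compound 3 `CN(C)c1ccc(/C=C(/Sc2ccc(Br)cc2)C(=O)c2ccc(Cl)cc2)cc1` likewise returns only a limit in this assay, > 100000 nM. The one readable movement is an at least 4.0-fold lower number from compound 2 to compound 1 (0.60 log units; beyond the scatter); its size is open at one end because the limit of > 100000 nM in this assay, at which 2 of the 3 values shown sit, leaves compound 2 without a number. The cores of compound 2 and compound 3 differ by bromo in place of methyl on an aromatic carbon, and the step that the two limits leave unreadable from compound 2 to compound 3 cannot be sized from two limits.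

Compound 4 `O=C(/C(=C\c1ccc(Br)cc1)Sc1ccc(Br)cc1)c1ccc(Cl)cc1` is not yet measured in this assay. It differs from compound 3 by bromo in place of dimethylamino on an aromatic carbon, the same change as from compound 2 to compound 1, made at the same place on the ring. That earlier change gave an at least 4.0-fold lower number from compound 2 to compound 1 (0.60 log units; beyond the scatter), so the step from compound 3 to compound 4 is expected to be of similar kind, an at least 4.0-fold lower number from compound 3 to compound 4 (0.60 log units; beyond the scatter), resting on compound 2 and compound 1 alone; with compound 3 at a limit, only the direction and a rough floor are carried over. Among the measured compounds shown here, compound 1, the one compound with a number, anchors the level. Compound 4 is therefore estimated at 25000 nM in this assay, with a range from 8000 nM to 90000 nM.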

Compound 4, concentration for 50% growth inhibition: 1000 nM
For compound 4 the middle estimate is 25-fold (1.40 log units) above the measured one; measured number below the stated range.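

The new step, an at least 100-fold lower number from compound 3 to compound 4 (2.00 log units; beyond the scatter), keeps the direction seen on the core of compound 1 for bromo in place of dimethylamino on an aromatic carbon in this assay: the same change on two cores in this assay, an at least 4.0-fold lower number (0.60 log units; beyond the scatter) from compound 2 to compound 1 and an at least 100-fold lower number (2.00 log units; beyond the scatter) from compound 3 to compound 4; the limit leaves it open whether they differ. The direction therefore carries across these two cores, but only a lower end is fixed for the size of each step, and the data do not show whether the change is larger on one core than on the other: the limit of > 100000 nM in this assay, at which 2 of the 4 values shown sit. The level reached after the change is also not set by the change alone, since bromo in place of methyl on an aromatic carbon, with 4-bromophenyl already in place on both compounds, gives a 25-fold lower number from compound 1 to compound 4 (1.40 log units; beyond the scatter).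

The compounds shown leave open how chloro or methoxy would stand in place of either bromo on the core of compound 4. They also leave open whether a primary amine, a carboxylic acid or a longer chain in place of 4-bromophenyl would hold the level of compound 4, and whether the two-core pattern extends to any core beyond these two.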